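This account rests on a few compounds, and the source may have more. Where it says the series, first, only, none or still open, it means among the compounds named here.

Measured so far in an ADME assay on BJ cells (Homo sapiens), read by MTT assay, with a stated time of 72 h (on this read-out higher numbers stand for weaker inhibition and lower numbers for stronger inhibition), for three compounds
Compound 1 `Cc1ncnc2c1c(-c1ccoc1)cn2[C@@H]1O[C@H](CO)[C@@H](O)[C@H]1O` gives 89200 nM
Compound 2 `COc1nc(N)nc2c1c(-c1ccoc1)cn2[C@@H]1O[C@H](CO)[C@@H](O)[C@H]1O` gives > 100000 nM as a limit
Compound 3 `Nc1nc2c(c(-c3ccco3)cn2[C@@H]2O[C@H](CO)[C@@H](O)[C@H]2O)c(=O)[nH]1` gives > 100000 nM as a limit

Compound 3 stands at the limit of > 100000 nM in this assay, at which 2 of the 3 values shown sit, and so has a limit, not a number. Compound 4 `Nc1nc2c(c(-c3cc4ccccc4o3)cn2[C@@H]2O[C@H](CO)[C@@H](O)[C@H]2O)c(=O)[nH]1` has not been measured yet. The change is 1-benzofuran-2-yl in place of furan-2-yl on an aromatic carbon in one place, 1-benzofuran-2-yl in place of furan-2-yl on an aromatic carbon.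

Among the compounds with values here, no two measured compounds differ in just one place, so the data give no direct size for such a swap. Within the data shown here, compound 1 at 89200 nM is the only true number here, and it shows no strong inhibition. A modest move towards stronger inhibition is therefore expected, though compound 4 could well stay at the limit. The expected size is an at least 2.0-fold lower number from compound 3 to compound 4 (0.30 log units; that floor lies within the scatter) as a rough estimate. Compound 4 is expected to read 50000 nM within an estimated range of 10000 nM to 100000 nM in this assay if a number is obtained.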

Compound 4, half-maximal inhibitory concentration: > 100000 nM
Compound 4: a limit, no number; the forecaster's own chance of this, stated with the estimate: 50%; middle value at least 2.0-fold (0.30 log units) from the limit.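

In this assay compound 3 and compound 4 each give a limit, not a number, so the step between them cannot be read. Both stand at the same place: the limit of > 100000 nM in this assay, at which 3 of the 4 values shown sit. The compounds shown leave open whether swapping furan-2-yl for 1-benzofuran-2-yl changes inhibition at all.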